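This account rests on a few compounds, and the source may have more. Where it says the series, first, only, none or still open, it means among the compounds named here.

Measured in a functional assay on P388 cells (Mus musculus) for cytotoxicity; a lower number here means a stronger inhibitor, a higher number a weaker inhibitor:
compound 1 `Cc1cc(-c2c(F)cc3c(=O)ccn(C4CC4)c3c2F)cc(C)n1`: 15000 nM
compound 2 `Cc1cc(-c2c(F)cc3c(=O)c(Cc4cccc(O)c4)cn(C4CC4)c3c2F)cc(C)n1`: 2200 nM
compound 3 `Cc1cc(-c2c(F)cc3c(=O)c(Cc4ccc[nH]4)cn(C4CC4)c3c2F)cc(C)n1`: 930 nM

Compound 3 has the lowest number of the three, and its steps to both others lie beyond the scatter. Compound 4 `Cc1cc(-c2c(F)cc3c(=O)c(Cc4ccccc4)cn(C4CC4)c3c2F)cc(C)n1` carries phenyl in place of 1H-pyrrol-2-yl on a saturated chain carbon bound to an aromatic carbon. The nearest measured change is the modest 2.4-fold lower number from compound 2 to compound 3 (0.37 log units; beyond the scatter), which brought in the same 1H-pyrrol-2-yl in place of 3-hydroxyphenyl. Within the data shown here, the large 16-fold lower number from compound 1 to compound 3 (1.21 log units; beyond the scatter) and the modest 6.8-fold lower number from compound 1 to compound 2 (0.83 log units; beyond the scatter) show only that both side groups lower the number. Among the measured compounds shown here, no measured compound carries the plain phenyl, so the reversed modest step of compound 2 is the best guide in this assay, and a modest move to a higher number is expected. The expected change is a 2.0-fold higher number from compound 3 to compound 4 (0.31 log units; beyond the scatter). The estimate for compound 4 is 1900 nM, with an expected range of 700 nM to 5000 nM.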

Compound 4, half-maximal inhibitory concentration: 7300 nM
Compound 4: middle estimate off by 3.8-fold (0.58 log units), on the low side; measured number outside the range, above it.
By their numbers in this assay, from the lowest: compound 3; then compound 2; then compound 4; then compound 1.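

In this assay, benzyl in place of hydrogen gives only a 2.1-fold lower number from compound 1 to compound 4 (0.31 log units; beyond the scatter), so a plain aromatic ring on this chain carbon accounts for little of the gain seen in the two substituted compounds. The ring itself decides the outcome: removing the hydroxy gives a 3.3-fold higher number from compound 2 to compound 4 (0.52 log units; beyond the scatter), and phenyl in place of 1H-pyrrol-2-yl gives a 7.8-fold higher number from compound 3 to compound 4 (0.89 log units; beyond the scatter). Nothing shown here accounts for these differences. Still open, on these data alone, is whether an amine or a carboxylic acid on the benzyl ring would match the hydroxy, and whether a longer chain would keep the lower numbers.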